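The source may hold more compounds than are shown below. What is called first, only, known or untested is meant among the compounds shown, and "the series" means these compounds.

Measured so far in a functional assay on HT-29 cells (Homo sapiens) for inhibition, read by sulforhodamine B assay, with a stated time of 48 h; a higher number here means a weaker inhibitor of growth, a lower number a stronger inhibitor of growth:
Compound 1 `Cc1cn([C@H]2C[C@H](CC3=CC(=O)C(=O)C=C3)[C@@H](CO[Si](C)(C)C(C)(C)C)O2)c(=O)[nH]c1=O`: no result reported
Compound 2 `COc1ccc(C2([C@H]3C[C@H](n4cc(C)c(=O)[nH]c4=O)O[C@@H]3CO[Si](C)(C)C(C)(C)C)SCCCS2)cc1OC`: 3890 nM

In this assay, for the measured compounds named here, compound 2 gives 3890 nM as the only number available, so it cannot yet be ranked against another compound. Against compound 2, compound 3 `COc1ccc(C2([C@H]3C[C@@H](n4cc(C)c(=O)[nH]c4=O)O[C@@H]3CO[Si](C)(C)C(C)(C)C)SCCCS2)cc1OC` shows this change: the two compounds have the same atoms and bonds and differ only in configuration as drawn: 1 of 3 stereo elements differ; a stereocentre at a saturated ring carbon is drawn R in compound 2 and S in compound 3 and no other. Going by the values given here, no measured pair shows what such a change in configuration does to growth inhibition. The expected 1.2-fold higher number from compound 2 to compound 3 (0.06 log units; within the scatter) is therefore no shift beyond the scatter, in either direction. Compound 3 is estimated at 4500 nM with an expected range from 1500 nM to 15000 nM in this read-out.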

Compound 3, concentration for 50% growth inhibition: 6170 nM
Compound 3: middle estimate off by 1.4-fold (0.14 log units), on the low side, and the stated range covers the measured number.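

For the compounds shown here, the pair gives the first reading of configuration at this saturated ring carbon: in this assay the redrawing from R to S gives a 1.6-fold higher number from compound 2 to compound 3 (0.20 log units; within the scatter) and so produces no shift beyond the scatter. Compounds 2 and 3 therefore show that, with this substitution, growth inhibition does not separate the two drawn forms. This comparison isolates configuration alone: the fact that compounds 2 and 3 differ only in the configuration as drawn.

As far as these compounds go, whether this holds for other substitution remains open, for example with a free hydroxyl group or an amine in place of the silyl ether. The pair also cannot show how the other two stereocentres bear on growth inhibition.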